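Methoxy removal on the dimethoxyphenyl arm of compound 1

The source may report more compounds than this note shows. Statements on the series, on what has been measured and on what is new or still open speak of the compounds shown alone.

Compound 1 `COc1ccc(C(=O)NNC(=O)c2ccc3[nH]c(-c4ccc([N+](=O)[O-])o4)nc3c2)cc1OC` gives 31.3 ug/mL in a functional assay on MCF7 cells (Homo sapiens) for inhibition, read by sulforhodamine B assay, with a stated time of 48 h; on this read-out lower numbers stand for stronger inhibition of growth and higher numbers for weaker inhibition of growth. Compound 3 `COc1cc(C(=O)NNC(=O)c2ccc3[nH]c(-c4ccc([N+](=O)[O-])o4)nc3c2)cc(OC)c1OC` gives 31.3 ug/mL, level with compound 1 at the digits shown; compound 2 `O=C(NNC(=O)c1cc2ccccc2cc1O)c1ccc2[nH]c(-c3ccc([N+](=O)[O-])s3)nc2c1` gives 62.5 ug/mL, a difference from compound 1 that stays within the scatter. Compound 4 `COc1cccc(C(=O)NNC(=O)c2ccc3[nH]c(-c4ccc([N+](=O)[O-])o4)nc3c2)c1` differs from compound 1 by hydrogen in place of methoxy on an aromatic carbon. Among the compounds with values here, the one step that bears on it runs the other way: no change at the digits printed from compound 1 to compound 3 (within the scatter), methoxy added on an aromatic carbon of the same ring with no change. Removing a methoxy from that ring is therefore expected to give no step beyond the scatter, no change at the digits printed from compound 1 to compound 4 (within the scatter). For compound 4 the expected value is 31.3 ug/mL, with a range from 15 ug/mL to 70 ug/mL.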

Compound 4, concentration for 50% growth inhibition: 15.6 ug/mL
Beside the measured number, compound 4's estimate is 2.0-fold (0.30 log units) above it; the range from low to high includes it.
By their numbers in this assay, from the lowest: compounds 4, 1, 3 and 2 (each within the scatter of the next, the first and the last beyond it).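

In this assay, within the data shown here, the change from 3,4-dimethoxyphenyl to 3-methoxyphenyl gives a 2.0-fold lower number from compound 1 to compound 4 (0.30 log units; within the scatter) and is the first reading of methoxy removal, at the place para to a large group. Methoxy on this ring has now been both added and removed with no step beyond the scatter. No measurement available here accounts for this result.

Open, as far as these compounds go, is whether this place responds to anything other than methoxy and hydrogen. An amine or a carboxylic acid there would test this, and the compounds shown say nothing about either group.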